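Adding a second cyano group to compound 2

This account rests on a few compounds, and the source may have more. Where it says the series, first, only, none or still open, it means among the compounds named here.

- compound 1 `N#Cc1cc(Cl)ccc1NC(=O)c1ccc2cccnc2c1O` gives 280 nM
- compound 2 `N#Cc1ccc(NC(=O)c2ccc3cccnc3c2O)cc1` gives 130 nM

In a functional assay on NALM-6 cells (Homo sapiens) for cytotoxicity, read by luminescence and CellTiter-Glo, with a stated time of 3 days (a lower number here means a stronger inhibitor, a higher number a weaker inhibitor), compound 2 gives 130 nM, the lower of the two numbers. Compound 1 gives 280 nM. The gap between these two numbers lies beyond the scatter.

Compound 3 `N#Cc1ccc(NC(=O)c2ccc3cccnc3c2O)c(C#N)c1` has cyano in place of hydrogen on an aromatic carbon, ortho to a large group and meta to a cyano group: cyano in place of hydrogen on an aromatic carbon.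

Within the data shown here, no single-place step has been measured in this assay. A small weakening is expected, possibly within the scatter. This rests on compound 1 at 280 nM, which also holds a cyano group ortho to a large group.

The expected change is a 1.5-fold higher number from compound 2 to compound 3 (0.19 log units; within the scatter).

For compound 3 the estimated value is 200 nM, with an expected range of 70 nM to 550 nM.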

Compound 3, half-maximal inhibitory concentration: 350 nM
Estimate against measurement, compound 3: 1.8-fold (0.24 log units) below, and the stated range covers the measured number.
By their numbers in this assay, from the lowest: compound 2; then compounds 1 and 3 (each within the scatter of the next).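

In this assay, among these compounds, cyano in place of hydrogen on an aromatic carbon, ortho to a large group and meta to a cyano group, gives the first single-place step, and it is a loss: a 2.7-fold higher number from compound 2 to compound 3 (0.43 log units; beyond the scatter), beyond the scatter. Cyano in place of chloro on an aromatic carbon gives a 1.3-fold higher number from compound 1 to compound 3 (0.10 log units; within the scatter), so the two groups are not told apart at that place. Nothing available here accounts for the loss.

On these data alone, whether an amine or a methoxy group ortho to the large group would carry the same cost remains open.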